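The compounds below may be only part of what the source reports. "The series", "measured", "known", "first", "only" and "open" are said of these compounds alone.

Measured so far:
Compound 1 `Cn1cncc1CN1CC(N(CC2CCN(C(=O)c3ccc(Cl)cc3)CC2)S(=O)(=O)c2ccccn2)Cc2cc(C#N)ccc21` gives 0.5 10^-6 cm/s
Compound 2 `Cn1cncc1CN1CC(N(CC2CCN(C(=O)c3ccccc3)CC2)S(=O)(=O)c2ccccn2)Cc2cc(C#N)ccc21` gives 0.5 10^-6 cm/s
Compound 3 `CC(C)NC(=O)N1CCC(CN(C2Cc3cc(C#N)ccc3N(Cc3cncn3C)C2)S(=O)(=O)c2ccccn2)CC1` gives 0.6 10^-6 cm/s

In an ADME assay on Caco-2 cells (Homo sapiens) for permeability, in the apical to basolateral direction (on this read-out higher numbers stand for higher permeability and lower numbers for lower permeability), these three numbers lie within the scatter of one another, so compound 3 stands level with compound 1 and compound 2. Compound 4 `Cn1cncc1CN1CC(N(CC2CCN(C(=O)NC(C)(C)C)CC2)S(=O)(=O)c2ccccn2)Cc2cc(C#N)ccc21` differs from compound 3 by methyl in place of hydrogen on a saturated chain carbon bound to an amide-type nitrogen and two saturated chain carbons and the isopropyl thus becomes tert-butyl. Among the measured compounds shown here, no step of exactly this kind has been measured. The closest evidence is the replacement of the whole group on the carbonyl, which gave a 1.2-fold higher number from compound 1 to compound 3 (0.08 log units; within the scatter) and also a 1.2-fold higher number from compound 2 to compound 3 (0.08 log units; within the scatter) while removing the chloro gave no change at the digits printed from compound 1 to compound 2 (within the scatter) as well. A step beyond the scatter is therefore not expected, and the estimate is no change at the digits printed from compound 3 to compound 4 (within the scatter) in this assay for this change. Compound 4 is expected at an estimated 0.6 10^-6 cm/s with a range from 0.3 10^-6 cm/s to 1.2 10^-6 cm/s when measured.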

Compound 4, apparent permeability: 0.6 10^-6 cm/s
For compound 4 middle estimate and measured number coincide at the digits printed; measured number inside the range.
By their numbers in this assay, from the lowest: compounds 1, 2, 3 and 4 (each within the scatter of the next).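

In this assay, the first step measured at this carbon itself, turning isopropyl into tert-butyl, gives no change at the digits printed from compound 3 to compound 4 (within the scatter). The (tert-butyl)amino group on the carbonyl carbon can also be compared with the two aromatic groups there: replacing phenyl gives a 1.2-fold higher number from compound 2 to compound 4 (0.08 log units; within the scatter), and replacing 4-chlorophenyl gives a 1.2-fold higher number from compound 1 to compound 4 (0.08 log units; within the scatter). No separate measurement is available to explain why these numbers stay within the scatter. From the compounds shown here alone, whether an amine or a carboxylic acid in place of one methyl of the tert-butyl would give a step beyond the scatter remains open.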